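The source may report more compounds than this note shows. Statements on the series, on what has been measured and on what is new or still open speak of the compounds shown alone.

Measured compounds:
Compound 1 `Cc1cc(C)cc(Oc2nc(NCCn3ccc(=O)[nH]c3=O)ncc2Cl)c1`: in an ADME assay on MT4 cells (Homo sapiens) for cytotoxicity, read by MTT assay, with a stated time of 5 days (on this read-out lower numbers stand for higher toxicity in this test and higher numbers for lower toxicity in this test), compound 1 gives > 322000 nM, which is a limit of the assay.
Compound 2 `Cc1cc(/C=C/C#N)cc(C)c1Oc1nc(NCCn2ccc(=O)[nH]c2=O)ncc1Cl`: in this assay compound 2 gives > 284000 nM, again a limit.
Compound 3 `Cc1cc(C#N)cc(C)c1Oc1nc(NCCn2ccc(=O)[nH]c2=O)ncc1Cl`: in this assay compound 3 gives > 11600 nM, also a limit.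

Compound 3 thus stands only at a limit, as do the other two (the limit of > 11600 nM in this assay, at which 1 of the 3 values shown sits, (the limit of > 284000 nM in this assay, at which 1 of the 3 values shown sits), (the limit of > 322000 nM in this assay, at which 1 of the 3 values shown sits)). Among the measured compounds shown here, the single step between measured compounds, a step that the two limits leave unreadable from compound 2 to compound 3, is not readable. Compound 4 `Cc1cc(C)c(Oc2nc(NCCn3ccc(=O)[nH]c3=O)ncc2Cl)c(C)c1` differs from compound 3 by methyl in place of cyano on an aromatic carbon. For the measured compounds named here, no measured step bears on this change, and every value is a limit, so no step beyond the scatter is expected in this assay. Compound 4 is expected at 200000 nM (range 40000 nM to 600000 nM). The step that the limit leaves unreadable from compound 3 to compound 4 is likewise an estimate, most likely reported as a further limit.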

Compound 4, half-maximal cytotoxic concentration: 2490 nM
The estimate for compound 4 lay 80-fold (1.90 log units) above the measured number; the whole stated range lies above it.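

Among the compounds shown here, with methyl on this aromatic carbon, para to a large group, this assay gives the first number that is not a limit, showing an at least 4.6-fold lower number from compound 3 to compound 4 (0.66 log units; beyond the scatter) and, with methyl in place of 2-cyanoethenyl, an at least 110-fold lower number from compound 2 to compound 4 (2.05 log units; beyond the scatter). With 2,4,6-trimethylphenyl in place of 3,5-dimethylphenyl on the oxygen, the record shows an at least 120-fold lower number from compound 1 to compound 4 (2.11 log units; beyond the scatter). Compound 3 stands only at a limit, so its step gives a minimum size only: the limit of > 11600 nM in this assay, at which 1 of the 4 values shown sits.

Still open, going by these compounds, is whether an amine or a carboxylic acid at this carbon would give a number or a limit. On these data alone, the true distance of compound 1, compound 2 and compound 3 from compound 4 also remains open.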